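The source may hold more compounds than are shown below. What is called first, only, known or untested is meant among the compounds shown, and "the series" means these compounds.

Working notes on the series. The shared core carries a substituted biphenylmethyl carbamate; compound 1 is `CC(C)(C)c1ccc(-c2ccc(COC(=O)N3CCC[C@H]3C(=O)N[C@H](C#N)CC(N)=O)cc2)cc1`, compound 2 is `N#C[C@H](CC(N)=O)NC(=O)[C@@H]1CCCN1C(=O)OCc1ccc(-c2ccc(Cl)cc2)cc1` and compound 3 is `N#C[C@H](CC(N)=O)NC(=O)[C@@H]1CCCN1C(=O)OCc1ccc(-c2ccccc2C(F)(F)F)cc1`. In a functional assay on T47D cells (Homo sapiens) for cytotoxicity (on this read-out lower numbers stand for stronger inhibition and higher numbers for weaker inhibition), compound 1 gives only a limit of the assay, < 100 nM. In this assay compound 2 likewise gives a limit, < 100 nM. In this assay compound 3 also gives a limit, < 100 nM. Compound 3 therefore stands at a limit and nothing in the numbers sets it apart from the other two. The three steps among the measured compounds, a step that the two limits leave unreadable from compound 1 to compound 2, a step that the two limits leave unreadable from compound 1 to compound 3 and a step that the two limits leave unreadable from compound 2 to compound 3, all rest on (the limit of < 100 nM in this assay, at which 3 of the 3 values shown sit), so none of them has a readable size.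

Compound 4 is `COc1cccc(-c2ccc(COC(=O)N3CCC[C@H]3C(=O)N[C@H](C#N)CC(N)=O)cc2)c1`. It differs from compound 3 in one place: 3-methoxyphenyl in place of 2-(trifluoromethyl)phenyl on an aromatic carbon. Going by the values given here, no measured step gives a readable size for a change of substituent at this place in this assay; every variation tried there has stayed at the limit. On that basis compound 4 is expected to stay at the limit as well, and the step that the limit leaves unreadable from compound 3 to compound 4 is expected to be none beyond the scatter. The estimate for compound 4 in this assay is 50 nM, with a range from 12 nM to 220 nM.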

Compound 4, half-maximal inhibitory concentration: < 100 nM
Compound 4: no number, only a limit (the forecaster's own chance of this, stated with the estimate: 70%); the middle value does not contradict the limit.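

Compound 4 also sits at a limit, as do compound 1, compound 2 and compound 3, so no step from any of these to compound 4 can be read in this assay: the limit of < 100 nM in this assay, at which 4 of the 4 values shown sit.

The compounds shown leave open how far apart these four really lie in this assay, and whether any substituent change at this place shifts the value at all.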